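Chromene series: pyrrolyl replacement at the benzoyl position

The source may hold more compounds than are shown below. What is called first, only, known or untested is meant among the compounds shown, and "the series" means these compounds.

Measured so far:
compound 1 `COc1ccc2c(c1)C(n1ccccc1=O)=CC(C)(C)O2` – 6.55
compound 2 `CC1(C)C=C(n2ccccc2=O)c2cc(C(=O)c3ccc(O)cc3)ccc2O1` – 6.65
compound 3 `Cc1ccccc1C(=O)c1ccc2c(c1)C(n1ccccc1=O)=CC(C)(C)O2` – 6.83

In a functional assay (aorta) with Rattus norvegicus as the target (a lower number here means a less potent compound, a higher number a more potent compound, by a factor of ten per unit of this negative logarithm), all three numbers sit within the scatter of one another: a number 0.28 log units higher from compound 1 to compound 3 (within the scatter) and a number 0.18 log units higher from compound 2 to compound 3 (within the scatter). Compound 3 therefore stands apart from neither neighbour.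

Compound 4 `Cc1ccc(C)n1-c1ccc2c(c1)C(n1ccccc1=O)=CC(C)(C)O2` is the next step from compound 3: 2,5-dimethyl-1H-pyrrol-1-yl in place of (2-methylphenyl)carbonyl on an aromatic carbon. Among the measured compounds shown here, the steps that bear on this position are a number 0.10 log units higher from compound 1 to compound 2 (within the scatter), a number 0.28 log units higher from compound 1 to compound 3 (within the scatter) and a number 0.18 log units higher from compound 2 to compound 3 (within the scatter), each within the scatter; every variation tried there so far has left this assay essentially unchanged. No step beyond the scatter is expected for compound 4 either. The expected step is a number 0.13 log units lower from compound 3 to compound 4 (within the scatter). Compound 4 is estimated at 6.7, within 6.2 to 7.2.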

Compound 4, logarithm of the reciprocal of the active concentration, log(1/C): 7.27
Estimate against measurement, compound 4: 0.57 log units below, and the stated range ends below it.
By their numbers in this assay, from the lowest: compounds 1, 2 and 3 (each within the scatter of the next); then compound 4.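

In this assay, among the compounds shown here, this aromatic carbon turns out to be sensitive to the group it carries: 2,5-dimethyl-1H-pyrrol-1-yl gives a number 0.44 log units higher from compound 3 to compound 4 (beyond the scatter) and a number 0.62 log units higher from compound 2 to compound 4 (beyond the scatter) and also a number 0.72 log units higher from compound 1 to compound 4 (beyond the scatter) in the first steps beyond the scatter. An aryl carbonyl is therefore not needed at this place for a high number in this assay. No evidence is available on what lies behind this gain.

On these data alone, the contribution of the two methyl groups on the pyrrole remains open. So does the effect of an unsubstituted pyrrol-1-yl, an amine or a carboxylic acid on this aromatic carbon.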